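The source may hold more compounds than are shown below. What is called first, only, known or untested is meant among the compounds shown, and "the series" means these compounds.

Of the compounds shown here, three have been tested so far in a functional assay on the whole organism with Mus musculus as the target; on this read-out higher numbers stand for an effect only at larger amounts of compound and lower numbers for an effect already at smaller amounts. Compound 1 `O=C1CCN(c2ccc(-c3ccc(Cl)cc3Cl)nn2)CC1` gives 7.3 mg/kg. Among the measured compounds shown here, compound 2 `CC(=O)OC1CCN(c2ccc(-c3ccc(Cl)cc3Cl)nn2)CC1` gives 9.8 mg/kg, a number within the usual scatter of the one for compound 1. Compound 3 `C/N=C(\S)OC1CCN(c2ccc(-c3ccccc3Cl)nn2)CC1` gives 20 mg/kg, a higher number than that of compound 2, and this gap lies beyond the scatter. Compound 2 therefore stands level with compound 1, and both need less compound for the effect than compound 3.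

Compound 4 `CNC(=O)OC1CCN(c2ccc(-c3ccc(Cl)cc3Cl)nn2)CC1` has not yet been measured. It differs from compound 2 in one place: methylamino in place of methyl on a carbonyl carbon. Methylamino stands in place of methyl on a carbonyl carbon, so acetoxy becomes (methylcarbamoyl)oxy.

For the measured compounds named here, no two measured compounds differ in only one place, so the data show no direct step for this change. Compound 3 differs from compound 2 in more than one place and cannot isolate it. Compound 2 at 9.8 mg/kg and compound 1 at 7.3 mg/kg do lie within the scatter of each other, although their groups on the shared core differ. On that thin evidence, no step beyond the scatter is expected in this assay, in either direction. The expected step of a 1.1-fold higher number from compound 2 to compound 4 (0.05 log units; within the scatter) is small. Compound 4 is estimated at 11 mg/kg, with an expected range from 4.5 mg/kg to 27 mg/kg.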

Compound 4, dose for half-maximal effect: 1.4 mg/kg
Estimate against measurement, compound 4: 7.9-fold (0.90 log units) above; measured number below the stated range.
By their numbers in this assay, from the lowest: compound 4; then compounds 1 and 2 (each within the scatter of the next); then compound 3.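

In this assay, the group on this carbonyl carbon turns out to matter: methylamino in place of methyl, which turns acetoxy into (methylcarbamoyl)oxy, gives a 7.0-fold lower number from compound 2 to compound 4 (0.85 log units; beyond the scatter). Among the compounds shown here, no earlier pair differed in only one place, so this is the first direct sign that a small edit here can change how much compound is needed for the effect, and the change runs toward smaller amounts. Methylamino brings a nitrogen and a hydrogen-bond donor that methyl lacks, but this single step cannot separate the roles of those features or of the larger group, and no measurement at hand explains the step.

The compounds shown leave open which feature of the new group carries the step: dimethylamino would keep the nitrogen without the amide hydrogen, while ethyl would replace the methyl with a carbon chain and no nitrogen. They also leave open how much room there is at this place, which a longer chain on the nitrogen, such as ethylamino, or a ring such as cyclopropylamino would begin to test.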